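A few compounds are considered here, and "the series" means these few. Any claim that something is new, unique, unknown or untested is made for them only; others in the source may bear on it.

Measured compounds in a functional assay on RAW264.7 cells (Mus musculus) for inhibition, with stated times of 2 h and 24 h; a lower number here means a stronger inhibitor, a higher number a weaker inhibitor:
Compound 1 `COc1ccc([C@@H]2c3c(OC)cc(OC)cc3C(O)[C@H]2c2cc(OC)cc(OC)c2)cc1` gives 7870 nM.
Compound 2 `COc1cc(OC)cc([C@@H]2C(O)c3cc(OC)cc(OC)c3[C@H]2c2ccccc2)c1` gives 3380 nM.
Compound 3 `COc1ccc(C(O)C2c3cc(OC)cc(OC)c3[C@@H](c3ccccc3)[C@@H]2c2cc(OC)cc(OC)c2)cc1` gives 16500 nM.

Among these three numbers compound 1 stands second highest, with compound 3 above it and compound 2 below it. The step from compound 1 to compound 2 shows a 2.3-fold lower number from compound 1 to compound 2 (0.37 log units; beyond the scatter), and the step from compound 2 to compound 3 shows a 4.9-fold higher number from compound 2 to compound 3 (0.69 log units; beyond the scatter).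

Compound 4 `COc1ccc([C@@H]2c3c(OC)cc(OC)cc3C(C(O)c3ccc(C)cc3)[C@H]2c2cc(OC)cc(OC)c2)cc1` arises from compound 1 by the change (hydroxy(4-methylphenyl)methyl in place of hydroxy on a saturated ring carbon). Among the compounds with values here, the closest precedent is the step from compound 2 to compound 3, where a hydroxy on the saturated ring carbon gave way to a hydroxy(4-methoxyphenyl)methyl group; that step weakened inhibition in this assay by a 4.9-fold higher number from compound 2 to compound 3 (0.69 log units; beyond the scatter). The change to compound 4 is of the same kind, differing only in the 4-methylphenyl in place of 4-methoxyphenyl, so a step of similar size toward a higher number is expected, namely a 4.1-fold higher number from compound 1 to compound 4 (0.61 log units; beyond the scatter). Compound 4 is therefore estimated at 32000 nM, within a range of 11000 nM to 90000 nM.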

Compound 4, half-maximal inhibitory concentration: 26500 nM
Beside the measured number, compound 4's estimate is 1.2-fold (0.08 log units) above it; the measured number falls inside the stated range.
By their numbers in this assay, from the lowest: compound 2; then compound 1; then compounds 3 and 4 (each within the scatter of the next).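

In this assay, the change has now been seen on a second background: a 3.4-fold higher number from compound 1 to compound 4 (0.53 log units; beyond the scatter). Until now, replacing the hydroxy on this saturated ring carbon with a larger hydroxy(aryl)methyl group had been seen only on compound 2, which carries a phenyl where compound 1 carries a 4-methoxyphenyl, so both listed steps of this kind now point toward weaker inhibition and neither goes against that direction. No measured evidence here accounts for that shift.

The two steps differ in both the background and the entering aromatic ring, so they cannot show which of those shapes the size of the change. On these data alone, it remains open how an amine or a carboxylic acid on this carbon would read, and whether a plain hydroxymethyl, without the aromatic ring, would shift the number in the same direction.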